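This account rests on a few compounds, and the source may have more. Where it says the series, first, only, none or still open, it means among the compounds named here.

Of the compounds shown here, three sharing one amide core have been measured in a physicochemical assay for solubility, at pH 7.4; a higher number here means a more soluble compound, a lower number a less soluble compound. Compound 3 `Cc1cc(C)c(-c2cccnc2)cc1NC(=O)c1ccc(OCc2ccccn2)cc1` gives 9000 nM, the highest number among them. Compound 1 `Cc1cc(C)c(-c2ncc[nH]2)cc1NC(=O)c1ccc(OCc2ccccn2)cc1` gives 2000 nM, so the step of a 4.5-fold higher number from compound 1 to compound 3 (0.65 log units; beyond the scatter) is a real rise. Compound 2 `Cc1csc(-c2cc(NC(=O)c3ccc(OCc4ccccn4)cc3)c(C)cc2C)n1` gives only a limit of this assay, < 1000 nM, and not a number. From that limit the step of an at least 9.0-fold higher number from compound 2 to compound 3 (0.95 log units; beyond the scatter) is a rise that can only be bounded, and the step of an at least 2.0-fold lower number from compound 1 to compound 2 (0.30 log units; that floor lies within the scatter) is a fall whose floor sits within the scatter.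

Compound 4 `Cc1cc(C)c(-c2cccc(N)n2)cc1NC(=O)c1ccc(OCc2ccccn2)cc1` has not yet been measured. Its difference from compound 3 is 6-aminopyridin-2-yl in place of pyridin-3-yl on an aromatic carbon: the ring is kept six-membered, but it is attached through a different carbon and carries an amino group. Every measured step swaps one small aromatic ring for another at this same position, and each such swap moved the number by a modest amount or less. None of them adds an amino group, so the measured steps set only the likely size of the effect, not its direction. The estimate for compound 4 is therefore a number close to that of compound 3, and the step of a 1.3-fold lower number from compound 3 to compound 4 (0.11 log units; within the scatter) is expected to stay within the scatter. Compound 4 is expected to give about 7000 nM, with a range from 2000 nM to 25000 nM.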

Compound 4, solubility: 2000 nM
Compound 4: middle estimate off by 3.5-fold (0.54 log units), on the high side; the range from low to high includes it.
By their numbers in this assay, from the lowest: compounds 1 and 4 (each within the scatter of the next); then compound 3. At a limit, below all of these: compound 2.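

In this assay, within the data shown here, placing 6-aminopyridin-2-yl in place of pyridin-3-yl gives a 4.5-fold lower number from compound 3 to compound 4 (0.65 log units; beyond the scatter), which shows that this position responds even when one six-membered aromatic ring with one hetero atom replaces another, whereas the earlier steps all changed the type of ring. Placing 6-aminopyridin-2-yl in place of 1H-imidazol-2-yl gives no change at the digits printed from compound 1 to compound 4 (within the scatter), so these two groups cannot be told apart in this assay, even though their rings differ in size. Placing 6-aminopyridin-2-yl in place of 4-methyl-1,3-thiazol-2-yl gives an at least 2.0-fold higher number from compound 2 to compound 4 (0.30 log units; that floor lies within the scatter), and this step can only be bounded because compound 2 gives a limit and not a number: the limit of < 1000 nM in this assay, at which 1 of the 4 values shown sits.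

The change from compound 3 alters both the carbon through which the ring is attached and the presence of an amino group, so the compounds shown cannot assign the fall to either one alone. As far as these compounds go, it also remains open how this position would respond to a pyridine ring attached in the same way but carrying no amino group, or to a methoxy group in place of the amino group.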